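A Methylpyridyl Swap at the Sulfonamide Nitrogen

This account rests on a few compounds, and the source may have more. Where it says the series, first, only, none or still open, it means among the compounds named here.

Three compounds were measured in a functional assay on CHO-K1 cells for antagonist activity at prostaglandin E2 receptor EP1 subtype (Homo sapiens), read by FLIPR and calcium flux; on this read-out higher numbers stand for weaker inhibition and lower numbers for stronger inhibition:

compound 1 `CCc1ccccc1N(CC(=O)NCc1ccc(Br)cc1)S(=O)(=O)c1ccc(C)cc1` gives 22.9 nM
compound 2 `CCc1ccccc1N(CC(=O)NCc1ccccc1OC)S(=O)(=O)c1ccc(C)cc1` gives 1070 nM
compound 3 `Cc1ccc(S(=O)(=O)N(CC(=O)NCc2ccc(Cl)cc2)c2cccnc2)cc1` gives < 1450 nM

For compound 3 the figure is not a number but a limit of the assay, (the limit of < 1450 nM in this assay, at which 1 of the 3 values shown sits), so compound 3 stands only loosely placed on the numbers shown. Compound 4 `Cc1ccc(S(=O)(=O)N(CC(=O)NCc2ccc(Cl)cc2)c2ccc(C)cn2)cc1` differs from compound 3 in one place: 5-methylpyridin-2-yl in place of pyridin-3-yl on a sulfonamide nitrogen. The only measured step among these compounds is a 47-fold higher number from compound 1 to compound 2 (1.67 log units; beyond the scatter), and that change sits on the saturated chain carbon bound to the amide-type nitrogen, not on the sulfonamide nitrogen. For the measured compounds named here, no measured step therefore bears directly on the change from compound 3 to compound 4; what remains is that compound 1, which carries a different group on the sulfonamide nitrogen, gives a low number, while compound 3 is known only as a limit. Against a limit, the expected step that the limit leaves unreadable from compound 3 to compound 4 can only be given loosely. Compound 4 is estimated to give 500 nM in this assay, with a range from 80 nM to 2000 nM, and a fair chance that this assay again reports only a limit.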

Compound 4, inhibition constant: < 1450 nM
Compound 4: only a limit was reported (the forecaster's own chance of this, stated with the estimate: 35%); the middle value is on the limit's open side.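

In this assay, compound 3 and compound 4 both stand at a limit of the assay rather than at a number, so no step can be read between them: the limit of < 1450 nM in this assay, at which 2 of the 4 values shown sit.

The compounds shown leave open whether 5-methylpyridin-2-yl in place of pyridin-3-yl on the sulfonamide nitrogen changes the read-out at all, and by how much.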